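A few compounds are considered here, and "the series" means these few. Any claim that something is new, unique, unknown or untested is made for them only; others in the source may bear on it.

Measured so far:
- compound 1 `COc1ccc(-c2cc3ccccc3nc2/C=C/C(=O)c2ccco2)cc1`: in a functional assay on MCF7 cells (Homo sapiens) for antiproliferative activity, read by XTT assay, with a stated time of 72 h (on this read-out higher numbers stand for weaker inhibition and lower numbers for stronger inhibition), compound 1 gives 710 nM
- compound 2 `COc1ccc(-c2cc3ccccc3nc2/C=C/C(=O)c2ccccn2)cc1`: in this assay compound 2 gives 810 nM

Compound 2 stands at the higher of the two numbers; its nearest neighbour is compound 1, and the step of a 1.1-fold higher number from compound 1 to compound 2 (0.06 log units; within the scatter) lies within the scatter. Compound 3 `COc1ccc(-c2cc3ccccc3nc2/C=C/C(=O)c2sccc2N)cc1` differs from compound 2 by 3-aminothiophen-2-yl in place of pyridin-2-yl on a carbonyl carbon. Going by the values given here, the only measured step that bears on a heteroaryl exchange at this carbonyl carbon is a 1.1-fold higher number from compound 1 to compound 2 (0.06 log units; within the scatter), which was within the scatter, so for compound 3 a step of a 1.1-fold lower number from compound 2 to compound 3 (0.03 log units; within the scatter) is expected, none beyond the scatter. For compound 3 in this assay the estimate is 750 nM, within 300 nM to 1900 nM.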

Compound 3, half-maximal inhibitory concentration: > 10000 nM
Compound 3: only a limit was reported; the forecaster's own chance of this, stated with the estimate: 5%; middle value at least 13-fold (1.12 log units) from the limit.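

On this carbonyl carbon, the substituent is not freely exchangeable: furan-2-yl and pyridin-2-yl lie within the scatter of each other, whereas 3-aminothiophen-2-yl brings an at least 12-fold higher number from compound 2 to compound 3 (1.09 log units; beyond the scatter) and an at least 14-fold higher number from compound 1 to compound 3 (1.14 log units; beyond the scatter) in this assay. The earlier pair showed no such sensitivity at this position. Compound 3 reads only as a limit: the limit of > 10000 nM in this assay, at which 1 of the 3 values shown sits.

On these data alone, whether the loss follows the amine or the thiophene ring remains open. A plain thiophen-2-yl on the same carbonyl carbon would separate the two.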